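This account rests on a few compounds, and the source may have more. Where it says the series, first, only, none or still open, it means among the compounds named here.

Compound 1, `C=CCn1c(=O)/c(=C\c2cccc(Cl)c2Cl)[nH]c(=O)/c1=C\c1ccccc1OC`, is the starting point of this account. In a functional assay on A549 cells (Homo sapiens) for cytotoxicity, read by CCK-8 assay, with a stated time of 72 h (on this read-out lower numbers stand for stronger inhibition and higher numbers for weaker inhibition), compound 1 gives 2300 nM, which is the highest of the two numbers reported in this assay. Its nearest neighbour is compound 2, `COc1ccccc1/C=c1\c(=O)[nH]/c(=C/c2cccc(Cl)c2Cl)c(=O)n1C`, which in this assay gives 200 nM; the step of a 12-fold lower number from compound 1 to compound 2 (1.06 log units; beyond the scatter) shows that a change at the nitrogen of the shared core can move the number far. Compound 3, `COc1ccccc1/C=c1/[nH]c(=O)/c(=C\c2ccccc2OC)[nH]c1=O`, carries a 2-methoxyphenyl on both sides of the core and is reported in this assay as "not active" (no number reported), without a number.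

The unmeasured compound 4, `C=CCn1c(=O)/c(=C\c2ccccc2F)[nH]c(=O)/c1=C\c1ccccc1OC`, differs from compound 1 by 2-fluorophenyl in place of 2,3-dichlorophenyl on a double-bonded chain carbon bound to an aromatic carbon. Within the data shown here, no measured step touches this position, so the single known step from compound 1 to compound 2 does not bear on it. What the data show is that compound 1, with the 2,3-dichlorophenyl, gives a number, whereas compound 3, without it, gives none. On this basis a step toward a higher number, beyond the scatter, is expected for compound 4, with a wide range, since the step from compound 1 to compound 4 is estimated as a 2.6-fold higher number from compound 1 to compound 4 (0.42 log units; beyond the scatter). Compound 4 is therefore expected to give about 6000 nM, between 2000 nM and 30000 nM.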

Compound 4, half-maximal inhibitory concentration: "not active" (no number reported)
The entry for compound 4 holds no number, so the estimate cannot be set against anything.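

In this assay, among these compounds, compound 4 is reported as "not active" without a number, so no step from compound 1 to compound 4 can be read. Nothing shown here bears on this result. The compounds shown leave open how far compound 4 lies from compound 1, and whether 2-fluorophenyl would also give no number on the core of compound 2.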